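The source may report more compounds than this note shows. Statements on the series, on what has been measured and on what is new or still open speak of the compounds shown alone.

Notes on the series. Compound 1 `OC[C@@H](O[C@H]1CCCN(Cc2ncc[nH]2)[C@H]1c1ccccc1)c1cc(Cl)cc(Cl)c1` is the reference point; in an assay on isolated protein for activation of cGMP-dependent protein kinase 1 (Homo sapiens), read by ADP-Glo, with stated times of 30 min and 2 h (on this read-out higher numbers stand for an effect only at larger amounts of compound and lower numbers for an effect already at smaller amounts), compound 1 reaches only the limit > 200000 nM, which is a boundary of the assay rather than a number, as recorded at the limit of > 200000 nM in this assay, at which 1 of the 3 values shown sits. Compound 2 `O=C(O)c1ccc2nc(CN3CCC[C@H](O[C@H](CO)c4cc(Cl)cc(Cl)c4)[C@@H]3c3ccccc3)[nH]c2c1` gives 43000 nM in this assay, and compound 3 `O=C(O)c1ccc(CN2CCC[C@H](O[C@H](CO)c3cc(Cl)cc(Cl)c3)[C@@H]2c2ccccc2)c([N+](=O)[O-])c1` gives 13000 nM. The measured steps all run one way: an at least 4.6-fold lower number from compound 1 to compound 2 (0.66 log units; beyond the scatter), an at least 15-fold lower number from compound 1 to compound 3 (1.18 log units; beyond the scatter), and a 3.3-fold lower number from compound 2 to compound 3 (0.52 log units; beyond the scatter). Both compounds that carry a carboxy group on an aromatic ring in place of the 1H-imidazol-2-yl of compound 1 sit at lower numbers than the limit of compound 1, with the 4-carboxy-2-nitrophenyl of compound 3 the lower of the two.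

Compound 4 `Cc1cc(C(=O)O)ccc1C(=O)N1CCC[C@H](O[C@H](CO)c2cc(Cl)cc(Cl)c2)[C@@H]1c1ccccc1` is not yet measured. It differs from compound 1 by a group of 12 heavy atoms (9 carbon, 3 oxygen; one six-membered aromatic ring of carbon only) in place of a group of 6 heavy atoms (4 carbon, 2 nitrogen; one five-membered aromatic ring with 2 hetero atoms), on an amine nitrogen in a ring. The step from compound 1 to compound 4 is therefore a change of the same kind as those to compound 2 and compound 3, with a carboxy-bearing aromatic ring taking the place of the imidazole, though here joined through a carbonyl rather than a methylene. On that basis the number for compound 4 in this assay is expected to fall below the limit of compound 1, by an at least 8.0-fold lower number from compound 1 to compound 4 (0.90 log units; beyond the scatter). The estimate for compound 4 is 25000 nM, within 5000 nM to 120000 nM.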

Compound 4, half-maximal effective concentration: > 200000 nM
Compound 4: no number, only a limit; the forecaster's own chance of this, stated with the estimate: 20%; middle value at least 8.0-fold (0.90 log units) from the limit.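

In this assay compound 4 gives > 200000 nM, a limit of the assay and not a number. Going by these compounds alone, compound 1 also stands at a limit, so no step between compound 1 and compound 4 can be read: the limit of > 200000 nM in this assay, at which 2 of the 4 values shown sit. The compounds shown leave open what the carbonyl join in compound 4 does on its own, as no pair shown differs in that one place.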